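A few compounds are considered here, and "the series" means these few. Any claim that something is new, unique, unknown or untested is made for them only; others in the source may bear on it.

The study compares three dimeric lactones for cytotoxicity in a functional assay on PANC-1 cells (Homo sapiens) for cytotoxicity, read by CellTiter-Glo, with a stated time of 72 h; a higher number here means a weaker inhibitor, a lower number a stronger inhibitor. For the measured compounds named here, compound 1 `C=C1C(=O)C2=C3[C@H]1[C@H]1OC(=O)C(=C)[C@@H]1CC[C@@]3(O)CC[C@]21C(=O)C[C@H]2C(=C)CC[C@H]3C(=C)C(=O)O[C@@H]3[C@H]21` is the only one of the pair already measured that returns a number: in this assay compound 1 gives 5400 nM. Compound 2 `C=C1C(=O)C2=C3[C@@H](CC[C@H]4C(=C)C(=O)O[C@@H]4[C@@H]13)CC[C@]21C(=O)C[C@H]2C(=C)CC[C@H]3C(=C)C(=O)O[C@@H]3[C@H]21` is the other measured compound. In this assay compound 2 reaches only a limit of the assay, > 10000 nM, which is the limit of > 10000 nM in this assay, at which 1 of the 2 values shown sits. On the numbers shown, compound 2 therefore stands at the unresolved end, with no figure of its own to compare. Compound 3 `C=C1C(=O)C2=C3[C@H](CC[C@H]4C(=C)C(=O)O[C@@H]4[C@@H]13)CC[C@]21C(=O)C[C@H]2C(=C)CC[C@H]3C(=C)C(=O)O[C@@H]3[C@H]21` is its unmeasured partner: the two compounds have the same atoms and bonds and differ only in configuration as drawn: 1 of 9 stereo elements differ; a stereocentre at a saturated ring carbon is drawn S in compound 2 and R in compound 3. Going by the values given here, no measured step connects the two, and a single change of drawn configuration gives no direction to lean on. The step expected in this assay is a step that the limit leaves unreadable from compound 2 to compound 3, none beyond the scatter, with a real chance that compound 3 also ends at a limit. Compound 3 is estimated at 12000 nM, within 4000 nM to 40000 nM.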

Compound 3, half-maximal inhibitory concentration: > 10000 nM
Compound 3: no number, only a limit; the forecaster's own chance of this, stated with the estimate: 60%; the middle value lies beyond the limit too.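

Moving from compound 2 to compound 3 changes one drawn stereocentre at a saturated ring carbon, and in this assay this does not bring a number out of either compound, so the step between them cannot be read: the fact that compounds 2 and 3 differ only in the configuration as drawn

Both compounds remain at a limit of the assay, which means this configuration alone does not separate them on the data shown: the limit of > 10000 nM in this assay, at which 2 of the 3 values shown sit.

Hydrogen in place of hydroxy on a saturated ring carbon gives the only readable comparison at this stage, an at least 1.8-fold higher number from compound 1 to compound 3 (0.26 log units; that floor lies within the scatter), and that figure is a floor, not a measured size.

The compounds shown leave open how far past the limit compound 2 and compound 3 lie, and so whether their configuration matters at all. They also leave open what an amine or a methoxy group would give in place of the hydroxy of compound 1.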